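Chloro to nitro on the lowest-reading compound

The source may hold more compounds than are shown below. What is called first, only, known or untested is meant among the compounds shown, and "the series" means these compounds.

- compound 1 `Cc1ccc(C(=O)CCN2CCN(c3ccc([N+](=O)[O-])cc3)CC2)cc1` gives 235000 nM
- compound 2 `COc1ccc(C(=O)CCN2CCN(c3ccc([N+](=O)[O-])cc3)CC2)cc1` gives 587000 nM
- compound 3 `O=C(CCN1CCN(c2ccc(Cl)cc2)CC1)c1ccc(C(F)(F)F)cc1` gives 54200 nM

All three numbers come from an ADME assay on Vero cells (Chlorocebus sabaeus) for cytotoxicity, read by resazurin assay, with a stated time of 72 h (on this read-out lower numbers stand for stronger inhibition and higher numbers for weaker inhibition), and compound 3 stands lowest among them, clearly apart from the other two.

The next compound to be tested is compound 4 `O=C(CCN1CCN(c2ccc([N+](=O)[O-])cc2)CC1)c1ccc(C(F)(F)F)cc1` which differs from compound 3 in one place, with nitro in place of chloro on an aromatic carbon. Going by the values given here, no measured pair shows this swap directly. Among the compounds with values here, the one measured step, a 2.5-fold higher number from compound 1 to compound 2 (0.40 log units; beyond the scatter) for methoxy in place of methyl on an aromatic carbon, concerns another group, so it mainly shows how far a single change can move the number in this small set.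

The better hint comes from the nitro compounds themselves. Compound 1 at 235000 nM and compound 2 at 587000 nM both carry 4-nitrophenyl and both read higher than compound 3, although they also lack its trifluoromethyl, so the hint is not clean. A moderate upward step in this assay is therefore expected. The estimate means an expected 2.4-fold higher number from compound 3 to compound 4 (0.38 log units; beyond the scatter) and remains uncertain. The estimated value for compound 4 is 130000 nM with an expected range of 55000 nM to 320000 nM (an expectation only).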

Compound 4, half-maximal inhibitory concentration: 75700 nM
For compound 4 the middle estimate is 1.7-fold (0.23 log units) above the measured one, within the range that was stated.
By their numbers in this assay, from the lowest: compounds 3 and 4 (each within the scatter of the next); then compound 1; then compound 2.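

In this assay, going from 4-chlorophenyl to 4-nitrophenyl gives a 1.4-fold higher number from compound 3 to compound 4 (0.15 log units; within the scatter) in the presence of trifluoromethyl, so in this one pair the swap at this aromatic carbon leaves the two compounds indistinguishable, and carrying 4-nitrophenyl does not by itself go with a high number. With 4-nitrophenyl held constant, the group at the other end of the molecule makes a clear difference: trifluoromethyl in place of methoxy gives a 7.8-fold lower number from compound 2 to compound 4 (0.89 log units; beyond the scatter) and trifluoromethyl in place of methyl gives a 3.1-fold lower number from compound 1 to compound 4 (0.49 log units; beyond the scatter) in the same read-out, both beyond the usual scatter. There is no independent measurement here that could explain any of these steps.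

Going by these compounds, all of this rests on a single chloro and nitro pair, so it remains open whether the two groups would also read alike with methyl or methoxy in place of trifluoromethyl. On these data alone, it is equally open how the number would respond to a quite different group on the same aromatic carbon, such as an amine or a carboxylic acid.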